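Cytotoxicity notes: fluorophenyl replaces furanyl at one position

The compounds below may be only part of what the source reports. "The series", "measured", "known", "first", "only" and "open" are said of these compounds alone.

Compound 1 `Cc1cc(C#N)cc(C)c1Oc1nc(Nc2ccc(C#N)cc2)ncc1-c1ccc(Cl)cc1` gives 72600 nM in an ADME assay on MT4 cells (Homo sapiens) for cytotoxicity, read by MTT assay, with a stated time of 5 days; a higher number here means that more compound is tolerated, a lower number that less compound is tolerated.
Compound 2 `Cc1cc(C#N)cc(C)c1Oc1nc(Nc2ccc(C#N)cc2)ncc1-c1ccoc1` gives 4980 nM in this assay.

Within the data shown here, compound 2 stands lowest of the two numbers in this assay; its only neighbour is compound 1, and the single measured step, a 15-fold lower number from compound 1 to compound 2 (1.16 log units; beyond the scatter), is large and beyond the scatter. Compound 3 `Cc1cc(C#N)cc(C)c1Oc1nc(Nc2ccc(C#N)cc2)ncc1-c1ccc(F)cc1` is not yet measured. 4-fluorophenyl in place of furan-3-yl on an aromatic carbon This change reverses the kind of exchange seen in that step, bringing a halogenated six-membered ring back in place of the five-membered ring, so a rise in this assay of a similar order is expected, an 8.0-fold higher number from compound 2 to compound 3 (0.90 log units; beyond the scatter). Compound 3 is accordingly estimated at 40000 nM, with a range of 10000 nM to 110000 nM.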

Compound 3, half-maximal cytotoxic concentration: 42700 nM
The estimate for compound 3 lay 1.1-fold (0.03 log units) below the measured number; the range from low to high includes it.
By their numbers in this assay, from the lowest: compound 2; then compounds 3 and 1 (each within the scatter of the next).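

Replacing furan-3-yl with 4-fluorophenyl on this aromatic carbon gives an 8.6-fold higher number from compound 2 to compound 3 (0.93 log units; beyond the scatter) in this assay and shows that the earlier gap is not specific to the chloro compound. Fluoro in place of chloro gives a 1.7-fold lower number from compound 1 to compound 3 (0.23 log units; within the scatter), so the two halogenated phenyl compounds both stand apart from compound 2. No measurement at hand bears on the cause of this gap.

Open, as far as these compounds go, is whether unsubstituted phenyl stands with these two compounds or with compound 2. Also open, from the compounds shown here alone, is where thiophene, another five-membered ring, or an aminomethyl or carboxylic acid group on the phenyl ring would fall.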